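The source may hold more compounds than are shown below. What is called first, only, known or untested is meant among the compounds shown, and "the series" means these compounds.

Measured series (a functional assay on P388 cells (Mus musculus) for cytotoxicity; on this read-out higher numbers stand for weaker inhibition and lower numbers for stronger inhibition)
- Compound 1 `C=C[C@@H]1NC(=O)[C@@H](C)NC(=O)[C@@H]2Cc3ccc(OC)c(c3)Oc3ccc(cc3)C[C@@H](C(=O)N2C)N(C)C(=O)[C@H](C)NC(=O)[C@H](Cc2ccc(OC)cc2)N(C)C1=O` gives 25.7 nM
- Compound 2 `C[C@@H]1NC(=O)[C@@H](C)NC(=O)[C@@H]2Cc3ccc(O)c(c3)Oc3ccc(cc3)C[C@@H](C(=O)N2C)N(C)C(=O)[C@H](C)NC(=O)[C@H](Cc2ccccc2)N(C)C1=O` gives 42.7 nM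
- Compound 3 `CCN1C(=O)[C@@H](C)NC(=O)[C@@H]2Cc3ccc(OC)c(c3)Oc3ccc(cc3)C[C@@H](C(=O)N2C)N(C)C(=O)[C@H](C)NC(=O)[C@H](Cc2ccc(OC)cc2)N(C)C(=O)[C@@H]1C` gives 43.7 nM

Compound 3 at 43.7 nM lies within the scatter of both other measured compounds, so these numbers set no order among the three. Compound 4 `C=C(C)CN1C(=O)[C@@H](C)NC(=O)[C@@H]2Cc3ccc(OC)c(c3)Oc3ccc(cc3)C[C@@H](C(=O)N2C)N(C)C(=O)[C@H](C)NC(=O)[C@H](Cc2ccc(OC)cc2)N(C)C(=O)[C@@H]1C` differs from compound 3 in one place, with 1-methylethenyl in place of methyl on a saturated chain carbon bound to an amide-type nitrogen in a ring. Cut one bond further out, the same difference reads ethyl to 2-methylprop-2-en-1-yl.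

Within the data shown here, no measured pair isolates a change in one place, so the data give no direct guide to its size or direction. The only support is the narrow spread of the series, with compound 2 at 42.7 nM and compound 1 at 25.7 nM also within the scatter of each other. The estimated change, a 1.0-fold higher number from compound 3 to compound 4 (0.01 log units; within the scatter), is expected to stay within the scatter, with no direction favoured. Compound 4 is estimated at 45 nM (expected range 20 nM to 100 nM).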

Compound 4, half-maximal inhibitory concentration: 11 nM
For compound 4 the middle estimate is 4.1-fold (0.61 log units) above the measured one; the whole stated range lies above it.
By their numbers in this assay, from the lowest: compound 4; then compounds 1, 2 and 3 (each within the scatter of the next).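

In this assay the exchange of methyl for 1-methylethenyl gives a 4.0-fold lower number from compound 3 to compound 4 (0.60 log units; beyond the scatter), so this position, on a saturated chain carbon bound to an amide-type nitrogen in a ring, does respond to substitution. Read one bond further out as ethyl to 2-methylprop-2-en-1-yl, the change shows that the larger unsaturated chain is accepted here and goes with stronger inhibition rather than weaker. Nothing available on these compounds accounts for the step.

Going by these compounds, whether the step depends on the double bond or on the added carbons stays open, and the saturated 2-methylpropyl chain would separate the two. Also open, on these data alone, is how far the trend extends at this position, for example to a longer chain such as pentyl or to a chain ending in an amine.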